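Replacing a Branched Amide Arm with a Carboxymethyl Amide

The source may hold more compounds than are shown below. What is called first, only, known or untested is meant among the compounds shown, and "the series" means these compounds.

Compound 1 `CC[C@@H](C)[C@H](NC(=O)c1ccc(C(CC)(CC)c2ccc(OCC(=O)C(C)(C)C)c(C)c2)n1CC)C(=O)OC` is one of three compounds tested in an assay on HL-60 cells for agonist activity at vitamin D3 receptor (Homo sapiens), read by microscopy, with a stated time of 96 h; on this read-out higher numbers stand for an effect only at larger amounts of compound and lower numbers for an effect already at smaller amounts. In this assay compound 1 gives 590 nM, the lowest of the three numbers. Compound 3 `C#CCCOC(=O)c1ccc(C(CC)(CC)c2ccc(OCC(O)C(C)(C)C)c(C)c2)n1CC` gives 1030 nM, which lies within the scatter of compound 1, whereas compound 2 `CCn1c(C(=O)N(C)CCC#N)ccc1C(CC)(CC)c1ccc(OCC(O)C(C)(C)C)c(C)c1` gives 1960 nM, a gap beyond the scatter. Compound 4 `CCn1c(C(=O)N(C)CC(=O)O)ccc1C(CC)(CC)c1ccc(OCC(=O)C(C)(C)C)c(C)c1` has not yet been measured. It differs from compound 1 on a carbonyl carbon whose other neighbour is an aromatic carbon of the shared core: (carboxymethyl)(methyl)amino in place of (1-(methoxycarbonyl)-2-methylbutyl)amino on a carbonyl carbon. For the measured compounds named here, only one measured step touches that same carbonyl carbon, a 1.9-fold lower number from compound 2 to compound 3 (0.28 log units; within the scatter), and it stays within the scatter, though it exchanges a nitrogen-linked group for an oxygen-linked one rather than one amide arm for another. Of the measured compounds, compound 2 most resembles compound 4 at that carbonyl carbon, and compound 2 gives 1960 nM. Compound 4 is therefore expected to show a moderately higher number, a 2.4-fold higher number from compound 1 to compound 4 (0.38 log units; beyond the scatter), with wide uncertainty. Compound 4 is estimated at 1400 nM, in a range from 350 nM to 5500 nM.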

Compound 4, half-maximal effective concentration: 1390 nM
Beside the measured number, compound 4's estimate is 1.0-fold (0.00 log units) above it, within the range that was stated.
By their numbers in this assay, from the lowest: compounds 1, 3, 4 and 2 (each within the scatter of the next, the first and the last beyond it).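

In this assay, for the compounds shown here, exchanging the (1-(methoxycarbonyl)-2-methylbutyl)amino arm for (carboxymethyl)(methyl)amino gives a 2.4-fold higher number from compound 1 to compound 4 (0.37 log units; beyond the scatter), a modest change, but the first at this carbonyl carbon to pass beyond the scatter; the only earlier step there, a 1.9-fold lower number from compound 2 to compound 3 (0.28 log units; within the scatter), stayed within it. The arm on this carbonyl carbon therefore does register in the read-out, and compound 4 still gives a number without the two defined stereocentres of the arm that leaves. Nothing available explains the size of this step.

The exchange alters the branched chain, the amide hydrogen and the ester at once, so the compounds shown leave open which of these carries the step. Comparing a (methoxycarbonylmethyl)(methyl)amino arm, which keeps the methyl ester on the shorter chain, with compound 4 would isolate the free carboxylic acid.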